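A few compounds are considered here, and "the series" means these few. Any claim that something is new, unique, unknown or untested is made for them only; others in the source may bear on it.

Compound 1 `Cc1ccc(CNC(=O)c2c(C)nc3cc(C)ccn23)cc1`: 54700 nM.
Compound 2 `COc1ccc(CNC(=O)c2c(C)nc3cc(C)ccn23)cc1`: > 128000 nM, a limit of the assay.

Both results come from an ADME assay on Vero cells (Chlorocebus sabaeus) for cytotoxicity, with a stated time of 72 h; on this read-out higher numbers stand for weaker inhibition and lower numbers for stronger inhibition. Compound 2 stands at the limit of > 128000 nM in this assay, at which 1 of the 2 values shown sits, so its place is known only as a limit and not as a number. Compound 3 `Cc1ccn2c(C(=O)NCc3ccc(Cl)cc3)c(C)nc2c1` carries chloro in place of methoxy on an aromatic carbon, para to a large group (chloro in place of methoxy on an aromatic carbon). Within the data shown here, the one measured step that bears on this change involves the same methoxy: an at least 2.3-fold higher number from compound 1 to compound 2 (0.36 log units; beyond the scatter). Compound 3 also loses that methoxy, so it is expected to give back at least part of an at least 2.3-fold higher number from compound 1 to compound 2 (0.36 log units; beyond the scatter), which would be a modest move to a lower number in this assay. The size of the move stays uncertain, as it starts from a limit. The estimated step is an at least 2.1-fold lower number from compound 2 to compound 3 (0.32 log units; beyond the scatter). The estimate for compound 3 is 60000 nM, expected within 25000 nM to 128000 nM.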

Compound 3, half-maximal inhibitory concentration in the Vero assay: > 128000 nM
Compound 3: only a limit was reported; the forecaster's own chance of this, stated with the estimate: 15%; middle value at least 2.1-fold (0.32 log units) from the limit.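

In the Vero assay, chloro on this aromatic carbon, para to a large group, gives no return towards compound 1, and the change from methyl reads as an at least 2.3-fold higher number from compound 1 to compound 3 (0.36 log units; beyond the scatter). Methoxy is therefore not the only group here that separates from methyl. In the Vero assay compound 2 gives > 128000 nM, a limit of the assay. In the Vero assay compound 3 gives > 128000 nM, also a limit of the assay. The step between these two cannot be read, because both sit at a limit of the assay: the limit of > 128000 nM in the Vero assay, at which 2 of the 3 values shown sit. In a physicochemical assay for solubility, in phosphate buffer, at pH 7.4 (a higher number here means a more soluble compound, a lower number a less soluble compound), compound 2 gives 148000 nM and compound 3 gives 25000 nM. In the physicochemical assay the same exchange can be read, as a 5.9-fold lower number from compound 2 to compound 3 (0.77 log units; beyond the scatter), so compound 2 and compound 3 do part in that read-out.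

The compounds shown leave open where compound 2 and compound 3 truly lie in the Vero assay, for both of which only limits are given. They also leave open whether an amine or a carboxylic acid at this place would bring the reading in the Vero assay back within the range of the assay.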